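Halogen-to-nitro swap on the hydroxybenzyl ring

This account rests on a few compounds, and the source may have more. Where it says the series, first, only, none or still open, it means among the compounds named here.

Measured compounds in a functional assay on MDA-MB-231 cells (Homo sapiens) for antiproliferative activity, read by WST assay, with a stated time of 72 h; a lower number here means a stronger inhibitor, a higher number a weaker inhibitor:
compound 1 `COC(=O)/C=C/c1ccc(NCc2ccccc2O)cc1` gives 31700 nM
compound 2 `COC(=O)/C=C/c1ccc(NCc2cc(Br)ccc2O)cc1` gives 109000 nM
compound 3 `COC(=O)/C=C/c1ccc(NCc2cc(Cl)ccc2O)cc1` gives 86400 nM

Compound 3 stands second highest of the three numbers, with compound 2 within the scatter of it and compound 1 the lowest number. Compound 4 `COC(=O)/C=C/c1ccc(NCc2cc([N+](=O)[O-])ccc2O)cc1` differs from compound 3 by nitro in place of chloro on an aromatic carbon. Among the compounds with values here, no measured step swaps a halogen for a nitro group here; the steps that bear on the position are a 2.7-fold higher number from compound 1 to compound 3 (0.44 log units; beyond the scatter) and a 3.4-fold higher number from compound 1 to compound 2 (0.54 log units; beyond the scatter), both modest rises on substitution of the hydrogen, while a 1.3-fold lower number from compound 2 to compound 3 (0.10 log units; within the scatter) shows the two halogens alike. A substituted ring at this place has so far given higher numbers than the unsubstituted one, so for compound 4 in this assay the expected step is a 1.2-fold higher number from compound 3 to compound 4 (0.06 log units; within the scatter), small and possibly upward. Compound 4 is estimated at 100000 nM, range 40000 nM to 250000 nM.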

Compound 4, half-maximal inhibitory concentration: 17400 nM
The estimate for compound 4 lay 5.7-fold (0.76 log units) above the measured number; the measured number lies below the stated range.
By their numbers in this assay, from the lowest: compounds 4 and 1 (each within the scatter of the next); then compounds 3 and 2 (each within the scatter of the next).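

In this assay, substitution para to a hydroxy group does not act as one effect: the nitro group parts from both halogens, with a 5.0-fold lower number from compound 3 to compound 4 (0.70 log units; beyond the scatter) and a 6.3-fold lower number from compound 2 to compound 4 (0.80 log units; beyond the scatter). The higher numbers of the halogen compounds are therefore no general penalty for any group at this place, since nitro in place of hydrogen stays within the scatter, with a 1.8-fold lower number from compound 1 to compound 4 (0.26 log units; within the scatter). Nothing available explains why nitro and the halogens part.

On these data alone, an amine or a carboxylic acid at this place remains open. So does a nitrile, which would test whether compound 4 stands alone.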